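Hydroxy in place of hydrogen on compound 2

The source may report more compounds than this note shows. Statements on the series, on what has been measured and on what is new or still open speak of the compounds shown alone.

In a functional assay on DU-145 cells (Homo sapiens) for inhibition, read by trypan blue exclusion, with a stated time of 96 h (a lower number here means a stronger inhibitor of growth, a higher number a weaker inhibitor of growth), compound 1 `O=C(/C(=C\c1c(O)cc(O)cc1O)S(=O)(=O)c1ccccc1Br)c1ccc(Br)cc1` gives 50000 nM. Compound 2 `O=C(/C(=C\c1ccc(O)cc1O)Sc1ccccc1Br)c1ccc(Br)cc1` gives 50000 nM, which stands level with compound 1 within the usual scatter, so neither of the two measured compounds leads in this assay.

The next compound is compound 3 `O=C(/C(=C\c1c(O)cc(O)cc1O)Sc1ccccc1Br)c1ccc(Br)cc1`, not yet measured. It follows from compound 2 through one structural change: hydroxy in place of hydrogen on an aromatic carbon. In words, this is hydroxy in place of hydrogen on an aromatic carbon, turning 2,4-dihydroxyphenyl into 2,4,6-trihydroxyphenyl.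

Among the measured compounds shown here, no two measured compounds differ in one place only, so the series offers no measured step by which to size this change. For the measured compounds named here, the only starting point is compound 2 at 50000 nM. The expectation in this assay is therefore a modest move towards stronger inhibition of growth, one that may well stay within the scatter. The estimate means a 1.4-fold lower number from compound 2 to compound 3 (0.15 log units; within the scatter), an expected step of small size. For compound 3 the estimated value is 35000 nM, with an expected range of 8000 nM to 70000 nM.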

Compound 3, concentration for 50% growth inhibition: > 100000 nM
Compound 3 was reported as a limit (the forecaster's own chance of this, stated with the estimate: 25%); at least 2.8-fold (0.45 log units) between middle value and limit.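

In this assay compound 3 is reported only as a limit, not as a number: the limit of > 100000 nM in this assay, at which 1 of the 3 values shown sits.

Among the compounds shown here, the hydroxy entering on the aromatic carbon, ortho to a large group and meta to two hydroxy groups, gives the first measured single-place step at this position, an at least 2.0-fold higher number from compound 2 to compound 3 (0.30 log units; that floor lies within the scatter), so turning 2,4-dihydroxyphenyl into 2,4,6-trihydroxyphenyl brings no measured gain in growth inhibition, though the floor of this step does not establish a loss. The second single-place step, with 2,4,6-trihydroxyphenyl held and (2-bromophenyl)sulfanyl in place of (2-bromophenyl)sulfonyl, reads an at least 2.0-fold higher number from compound 1 to compound 3 (0.30 log units; that floor lies within the scatter), and it likewise shows no gain while its floor establishes no loss.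

On these data alone, how far compound 3 lies past its limit stays open, and with it the full size of both steps. Also open, as far as these compounds go, is how a methoxy group, an amine or a carboxylic acid on the same aromatic carbon would read against compound 2 in this assay.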